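The compounds below may be only part of what the source reports. "The series", "measured", "known", "first", "only" and "open" are said of these compounds alone.

Among the compounds with values here, compound 2, `Cc1cc(O)c(C2=NN(c3ccc(S(N)(=O)=O)cc3)C(/C=C/c3ccccc3)C2)cc1Cl`, stands highest of the two numbers so far in a functional assay on MDA-MB-231 cells (Homo sapiens) for antiproliferative activity, with a stated time of 48 h (on this read-out lower numbers stand for stronger inhibition of growth and higher numbers for weaker inhibition of growth), giving 4560 nM. Compound 1, `Cc1cc(O)c(C2=NN(c3ccc(S(N)(=O)=O)cc3)C(c3ccccc3Cl)C2)cc1Cl`, gives 2140 nM in this assay. Within the data shown here, only one measured step bears on the change ahead: a 2.1-fold higher number from compound 1 to compound 2 (0.33 log units; beyond the scatter), a modest rise at the same saturated ring carbon. Compound 3, `COc1ccc(C2CC(c3cc(Cl)c(C)cc3O)=NN2c2ccc(S(N)(=O)=O)cc2)cc1OC`, differs from compound 2 by 3,4-dimethoxyphenyl in place of 2-phenylethenyl on a saturated ring carbon, so an aromatic ring returns to that position. Because of a 2.1-fold higher number from compound 1 to compound 2 (0.33 log units; beyond the scatter), compound 3 is expected to move back toward the number of compound 1, a modest fall of about a 1.9-fold lower number from compound 2 to compound 3 (0.28 log units; within the scatter). The estimate for compound 3 is therefore 2400 nM, within 1000 nM to 5500 nM.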

Compound 3, concentration for 50% growth inhibition: 3810 nM
For compound 3 the middle estimate is 1.6-fold (0.20 log units) below the measured one; the range from low to high includes it.
By their numbers in this assay, from the lowest: compounds 1, 3 and 2 (each within the scatter of the next, the first and the last beyond it).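

In this assay, the step of a 1.2-fold lower number from compound 2 to compound 3 (0.08 log units; within the scatter) and the step of a 1.8-fold higher number from compound 1 to compound 3 (0.25 log units; within the scatter) show that 3,4-dimethoxyphenyl on the saturated ring carbon cannot be told apart from either 2-phenylethenyl or 2-chlorophenyl. Within the data shown here, the entry of two hydrogen-bond acceptors at this place thus gives no change that can be read, and the only step beyond the scatter remains the one between compound 1 and compound 2. The compounds shown leave open whether an amine or a carboxylic acid on this carbon would shift the number beyond the scatter. No measured evidence bears on these results.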